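The source may report more compounds than this note shows. Statements on the series, on what has been measured and on what is new or still open speak of the compounds shown alone.

In an assay on CHO cells for displacement of a labelled ligand from adenosine receptor A3 (Homo sapiens), read by scintillation counting, tested at 1 uM (on this read-out lower numbers stand for less inhibition and higher numbers for more inhibition at the one concentration tested (going by the name of the read-out)), compound 1 `Cc1cccc(Cc2nc(N)c3nn(-c4ccccc4)cc3n2)c1` gives 11%, the lowest of the three numbers measured. Compound 2 `Cc1ccc(Cc2nc(N)c3nn(-c4ccccc4)cc3n2)cc1` gives 39% and compound 3 `COc1ccc(CCc2nc(N)c3nn(-c4ccccc4)cc3n2)cc1` gives 22%, each beyond the scatter above compound 1. The change from compound 1 to compound 4 `Nc1nc(CCc2ccc(O)cc2)nc2cn(-c3ccccc3)nc12` is 4-hydroxybenzyl in place of 3-methylphenyl on a saturated chain carbon bound to an aromatic carbon. For the measured compounds named here, only one measured step bears on it: a number 28 percentage points higher from compound 1 to compound 2 (beyond the scatter), which also replaces 3-methylphenyl by a ring carrying its single substituent as in 4-methylphenyl, and that step was modest. Going by the values given here, compound 3 carries a group that resembles 4-hydroxybenzyl more closely than either methylphenyl does, and its value sits beyond the scatter above compound 1 but well under compound 2; no single-change step links compound 3 to compound 4, so its value can only serve as a rough anchor. On this basis a modest rise in this assay is expected, a number 14 percentage points higher from compound 1 to compound 4 (beyond the scatter). Compound 4 is therefore estimated to give 25%, with a range from 8% to 45%.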

Compound 4, a percentage reported as inhibition, at one concentration (the size of the read-out at that concentration, not a potency): 37%
Compound 4: the middle estimate sits 12 percentage points below what was measured; the measured number falls inside the stated range.
By their numbers in this assay, from the lowest: compound 1; then compound 3; then compounds 4 and 2 (each within the scatter of the next).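

In this assay hydrogen in place of methyl on an oxygen on an aromatic ring gives a number 15 percentage points higher from compound 3 to compound 4 (beyond the scatter) and so shows that this single change on the oxygen is enough to move the number. The swap of 4-methylphenyl for 4-hydroxybenzyl gives a number 2 percentage points lower from compound 2 to compound 4 (within the scatter) and so leaves the two groups indistinguishable at the one concentration tested. Replacing 3-methylphenyl with 4-hydroxybenzyl gives a number 26 percentage points higher from compound 1 to compound 4 (beyond the scatter) and thus adds a second group, after 4-methylphenyl, that stands beyond the scatter above 3-methylphenyl.

From the compounds shown here alone, whether an amine or a carboxylic acid in place of the hydroxyl on that ring, or a longer chain to the ring, would hold or shift the number remains open. Nothing measured here explains why these changes have the sizes they do.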